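The compounds below may be only part of what the source reports. "The series", "measured", "known", "first", "only" and "open" are said of these compounds alone.

Working notes on the series, read in a functional assay on B16-F10 cells (Mus musculus) for antiproliferative activity, read by CCK-8 assay, with a stated time of 48 h; a higher number here means a weaker inhibitor, a lower number a stronger inhibitor. Compound 1 `COc1ccc(/C=C\c2cc(OC)c(OC)c(OC)c2)cc1OCc1ccc(CNC(C)(C)C(=O)O)cc1` gives > 10000 nM, which is a limit of the assay and not a number. Among the measured compounds shown here, compound 2 `COc1ccc(/C=C\c2cc(OC)c(OC)c(OC)c2)cc1OCc1ccc(CN2CC[C@H](C(=O)O)C2)cc1` gives 7000 nM, the only true number so far.

Compound 3 `COc1ccc(/C=C\c2cc(OC)c(OC)c(OC)c2)cc1OCc1ccc(CNCCN(C)C)cc1` differs from compound 2 on a saturated chain carbon bound to an aromatic carbon, where (2-(dimethylamino)ethyl)amino stands in place of 3-carboxypyrrolidin-1-yl: (2-(dimethylamino)ethyl)amino in place of 3-carboxypyrrolidin-1-yl on a saturated chain carbon bound to an aromatic carbon.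

For the measured compounds named here, one measured step bears on this, an at least 1.4-fold lower number from compound 1 to compound 2 (0.15 log units; that floor lies within the scatter). It is small, and it exchanges one carboxy-bearing group for another. Going by the values given here, the group entering in compound 3 has no carboxy group, so no measured step covers this change and the size of the new step is poorly constrained. A moderate move to a lower number in this assay is expected, held with low confidence.

The estimated step is a 4.7-fold lower number from compound 2 to compound 3 (0.67 log units; beyond the scatter). For compound 3 the expected value is 1500 nM, with an estimated range of 150 nM to 9000 nM.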

Compound 3, half-maximal inhibitory concentration: > 10000 nM
Compound 3 gave a limit, no number (the forecaster's own chance of this, stated with the estimate: 15%); middle value at least 6.6-fold (0.82 log units) away from the limit.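

In this assay, (2-(dimethylamino)ethyl)amino in place of 3-carboxypyrrolidin-1-yl on a saturated chain carbon bound to an aromatic carbon gives an at least 1.4-fold higher number from compound 2 to compound 3 (0.15 log units; that floor lies within the scatter), so this side chain without a carboxy group does not give a readable number at this place. The step from compound 1 to compound 3 cannot be read, as both values are limits of the assay and not numbers. The side chains shown at this place therefore remain only partly ranked, with compound 2 alone giving a true number: the limit of > 10000 nM in this assay, at which 2 of the 3 values shown sit.

As far as these compounds go, it remains open whether the ring of compound 2 or its carboxy group goes with the readable value, which a plain pyrrolidine without the carboxylic acid would help to separate. Also open, from the compounds shown here alone, is whether any group at this place can give a value well below the limit, for example a longer chain ending in a dimethylamino group, a piperidine or a neutral amide.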